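The compounds below may be only part of what the source reports. "The series", "measured", "known", "first", "only" and "open" are said of these compounds alone.

Measured in a functional assay on SK-N-SH cells (Homo sapiens) for cytotoxicity, read by sulforhodamine B assay, with a stated time of 48 h; on this read-out lower numbers stand for stronger inhibition and higher numbers for weaker inhibition:
compound 1, `CO[C@@H]1CC=C2NN(c3c[nH]c4ccccc34)C(=O)CC[C@]2(c2ccccc2)O1`, gives 1000 nM
compound 2, `CO[C@@H]1CC=C2NN(c3cc(Cl)cc(Cl)c3)C(=O)CC[C@]2(c2ccccc2)O1`, gives 7110 nM
compound 3, `CO[C@@H]1CC=C2N(c3c[nH]c4ccccc34)C(=O)C[C@]2(c2ccccc2)O1`, gives 8200 nM

Compound 1 and compound 2 share one core and differ in a single place: 3,5-dichlorophenyl in place of 1H-indol-3-yl on an amide-type nitrogen in a ring. That change brought a 7.1-fold higher number from compound 1 to compound 2 (0.85 log units; beyond the scatter) in this assay. Among the compounds with values here, compound 3 carries a different core; how it differs from compound 1 is not broken down here, and the two values show only that compound 3 sits well above compound 1 in this assay, while compound 3 and compound 2 lie within the usual scatter of each other.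

Compound 4, `CO[C@@H]1CC=C2N(c3cc(Cl)cc(Cl)c3)C(=O)C[C@]2(c2ccccc2)O1`, has not been measured. It stands to compound 3 as compound 2 stands to compound 1: 3,5-dichlorophenyl in place of 1H-indol-3-yl on an amide-type nitrogen in a ring. The place is not the same word for word, since in compound 3 the amide-type nitrogen belongs to a five-membered non-aromatic ring with 1 nitrogen, two ring bonds from the ring atom that bears a fused ring and two ring bonds from the ring atom that bears a phenyl group, whereas in compound 1 it belongs to a seven-membered non-aromatic ring with 2 nitrogen, next to the ring nitrogen, three ring bonds from each of those atoms. It is therefore the same kind of change, not the same change.

For compound 4 a step of a 3.7-fold higher number from compound 3 to compound 4 (0.56 log units; beyond the scatter) in this assay is expected, weaker than the earlier one because that earlier step, a 7.1-fold higher number from compound 1 to compound 2 (0.85 log units; beyond the scatter), was seen on a different core and compound 3 already starts high at 8200 nM. Compound 4 is thus estimated at 30000 nM, between 7000 nM and 130000 nM, with a real chance that only a limit is reported.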

Compound 4, half-maximal inhibitory concentration: 9670 nM
Beside the measured number, compound 4's estimate is 3.1-fold (0.49 log units) above it; the range from low to high includes it.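

In this assay, placing 3,5-dichlorophenyl instead of 1H-indol-3-yl on the amide-type nitrogen of the five-membered non-aromatic ring gave a 1.2-fold higher number from compound 3 to compound 4 (0.07 log units; within the scatter), so on this core the exchange of groups made no readable difference. The same kind of change therefore did not carry over with its size from one core to the other, and the two steps differ by more than the scatter allows: the same change on two cores in this assay, a 7.1-fold higher number (0.85 log units; beyond the scatter) from compound 1 to compound 2 and a 1.2-fold higher number (0.07 log units; within the scatter) from compound 3 to compound 4, 6.0-fold (0.78 log units) apart, beyond the scatter of two such steps This shows that, within these two pairs, the size of the step depends on the core, but with a single pair on each core it does not show which feature of the cores is responsible, nor does it give a rule for any other group placed on that nitrogen.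

On these data alone, only 1H-indol-3-yl and 3,5-dichlorophenyl appear on that nitrogen, so it remains open whether an amine, a carboxylic acid or a longer alkyl chain in the same place would also respond differently on the two cores. The phenyl group is the same in all the compounds shown, and it also remains open whether a pyridine ring there would alter the gap between the two cores.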